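The source may hold more compounds than are shown below. What is called first, only, known or untested is meant among the compounds shown, and "the series" means these compounds.

The series is compared in an assay on cells for inhibition of Palmitoleoyl-protein carboxylesterase NOTUM variant C330S (Homo sapiens), read by fluorescence, with a stated time of 40 min; on this read-out higher numbers stand for weaker inhibition and lower numbers for stronger inhibition. Compound 1 `Cc1cc(C(=O)O)c(C)n1-c1cccc(C(C)(C)C)c1` gives 460 nM in this assay. For the measured compounds named here, compound 2 `CC(C)c1cccc(N2CCC(C(=O)O)C2)c1` gives 57000 nM in this assay, the highest of the two numbers recorded, and its only neighbour is compound 1, whose number lies well beyond the scatter below it. Compound 3 `O=C(O)C1CCN(c2cccc(OC(F)(F)F)c2)C1` has not yet been measured. It differs from compound 2 in one place: trifluoromethoxy in place of isopropyl on an aromatic carbon. Going by the values given here, no pair of measured compounds shows this particular exchange, so there is no direct step to lean on. A change that leaves the shared core and the acid untouched is expected to move this assay only modestly; the step from compound 2 to compound 3 is estimated at a 1.9-fold lower number from compound 2 to compound 3 (0.28 log units; within the scatter), leaning towards a lower number. Compound 3 is therefore expected to give about 30000 nM in this assay, within a range from 8000 nM to 120000 nM.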

Compound 3, half-maximal inhibitory concentration: 63000 nM
Compound 3: middle estimate off by 2.1-fold (0.32 log units), on the low side; low and high end bracket the measured number.
By their numbers in this assay, from the lowest: compound 1; then compounds 2 and 3 (each within the scatter of the next).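

In this assay, trifluoromethoxy in place of isopropyl on an aromatic carbon gives a 1.1-fold higher number from compound 2 to compound 3 (0.04 log units; within the scatter). For the compounds shown here, this is the first direct reading of an exchange at this position, and it shows that this assay does not separate the two groups on this core, even though trifluoromethoxy brings more heavy atoms and a hydrogen-bond acceptor that isopropyl lacks. No available measurement bears on why the two groups read alike.

From the compounds shown here alone, whether an amine or a longer chain at this place would read differently from these two groups remains open. Also open, going by these compounds, is whether a change between isopropyl and trifluoromethoxy would read the same way on the core of compound 1, or whether an amide in place of the carboxylic acid would be tolerated.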